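Cytotoxicity notes: from compound 1 to compound 4

The compounds below may be only part of what the source reports. "The series", "measured", "known", "first", "only" and "open" are said of these compounds alone.

Compound 1 `Cc1ccc(-c2nn(-c3ccc(F)cc3F)cc2CNCCN2CCN(C)CC2)cc1` has been run in an ADME assay on Huh-7 cells (Homo sapiens) for cytotoxicity; a lower number here means that less compound is tolerated, a higher number that more compound is tolerated. In this assay compound 1 returns only a limit, > 20000 nM, and no number. Compound 2 `Cc1ccccc1-c1nn(Cc2ccc(F)cc2)cc1CNCCN1CCN(C)CC1` in this assay likewise gives only the limit > 20000 nM. Compound 3 `Cc1ccccc1-c1nn(-c2cc(F)ccc2F)cc1CNCCN1CCN(C)CC1` in this assay also gives only the limit > 20000 nM. Among the measured compounds shown here, the single step between measured compounds that differ in one place, a step that the two limits leave unreadable from compound 2 to compound 3, cannot be read because both ends are limits. Every value recorded so far sits at the limit of > 20000 nM in this assay, at which 3 of the 3 values shown sit, so compound 1 stands exactly where the rest of the series stands.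

Compound 4 `CN1CCN(CCNCc2cn(-c3ccc(F)cc3F)nc2C(C)(C)C)CC1` is not yet measured. It differs from compound 1 by tert-butyl in place of 4-methylphenyl on an aromatic carbon. For the measured compounds named here, no measured step bears on this change: the only step recorded concerns the group on the aromatic nitrogen and is itself unreadable. Given (the limit of > 20000 nM in this assay, at which 3 of the 3 values shown sit), the expected step is a step that the limit leaves unreadable from compound 1 to compound 4, meaning none beyond the scatter. Compound 4 is therefore estimated to give 30000 nM in this assay, within a range from 10000 nM to 100000 nM, and most likely again only as a limit.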

Compound 4, half-maximal cytotoxic concentration: > 20000 nM
Compound 4: no number, only a limit; the forecaster's own chance of this, stated with the estimate: 85%; the middle value does not contradict the limit.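

Compound 1 and compound 4 both give only a limit in this assay and so yield no readable step for tert-butyl in place of 4-methylphenyl: (the limit of > 20000 nM in this assay, at which 4 of the 4 values shown sit). The compounds shown leave open whether any change on the shared core shifts the half-maximal cytotoxic concentration at all.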